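The source may hold more compounds than are shown below. What is called first, only, known or untested is meant among the compounds shown, and "the series" means these compounds.

Measured compounds:
Compound 1 `CC(=O)Nc1ccc(S(=O)(=O)NNC(=O)c2cccnc2Nc2ccc(Cl)cc2)cc1` gives > 100000 nM in a functional assay on SF-295 cells (Homo sapiens) for antiproliferative activity; on this read-out lower numbers stand for stronger inhibition of growth and higher numbers for weaker inhibition of growth.
Compound 2 `O=C(NNS(=O)(=O)c1ccc(F)cc1)c1cccnc1Nc1ccc(Cl)cc1Cl` gives > 100000 nM in this assay.

Both of these values are limits of the assay and not numbers. Compound 1 stands at that limit, as does every value shown here: the limit of > 100000 nM in this assay, at which 2 of the 2 values shown sit. Compound 2 likewise stands at the limit in this assay, so nothing separates the two measured compounds on the numbers available.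

Compound 3 `O=C(NNS(=O)(=O)c1ccc(Cl)cc1Cl)c1cccnc1Nc1ccc(Cl)cc1` has not yet been measured. It differs from compound 1 in one place: 2,4-dichlorophenyl in place of 4-acetamidophenyl on a sulfonyl sulfur. Among the measured compounds shown here, no step between measured compounds exists in this set, so no measured change of any size in this assay can be pointed to. With compound 1 at the limit, the step from compound 1 to compound 3 in this assay is expected to be a number no higher from compound 1 to compound 3 (the limit leaves the size open), none beyond the scatter. Compound 3 is therefore expected to give about 100000 nM, within a range from 30000 nM to 300000 nM, and most probably only a limit once more.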

Compound 3, concentration for total growth inhibition: 77600 nM
The estimate for compound 3 lay 1.3-fold (0.11 log units) above the measured number, and the stated range covers the measured number.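

In this assay, compound 3 gives 77600 nM, a measured number rather than a limit, so a read-out inside the range of the assay can be obtained with a change at this position alone. Compound 1 gives > 100000 nM, which is a limit of the assay. With 2,4-dichlorophenyl in place of 4-acetamidophenyl on a sulfonyl sulfur, the step is an at least 1.2-fold lower number from compound 1 to compound 3 (0.11 log units; that floor lies within the scatter), and this is only a floor, so the change is not shown to do more than reach a number.

As far as these compounds go, the true size of the step stays open, as most values still stand at the limit: the limit of > 100000 nM in this assay, at which 2 of the 3 values shown sit. It also remains open whether an amine or a carboxylic acid on the sulfonyl sulfur's aryl ring would give a number in this assay.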